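This account rests on a few compounds, and the source may have more. Where it says the series, first, only, none or still open, it means among the compounds named here.

Three compounds have so far been measured in an ADME assay on cells (Hepatocyte, Rattus norvegicus) for metabolic stability, read by HPLC, with a stated time of 30 min, tested at 1 uM; a lower number here means slower removal, a higher number faster removal of the compound:

Compound 1, `C[C@H](Nc1c(C(N)=O)nnc2ccc(-c3ccc(OCCCN(C)C)nc3)cc12)C1CCOCC1`, gives 3.4 uL/min.
Compound 2, `C[C@H](Nc1c(C(N)=O)nnc2ccc(-c3ccc(OCCCN(C)C)nc3)cc12)c1ccn(C)n1`, gives 7 uL/min.
Compound 3, `Cc1cn(C)nc1[C@H](C)Nc1c(C(N)=O)nnc2ccc(-c3ccc(OCCCN(C)C)nc3)cc12`, gives 12 uL/min.

Compound 1 stands lowest of the three. The step of a 2.1-fold higher number from compound 1 to compound 2 (0.31 log units; beyond the scatter) and the step of a 3.5-fold higher number from compound 1 to compound 3 (0.55 log units; beyond the scatter) both lie beyond the scatter, while the step of a 1.7-fold higher number from compound 2 to compound 3 (0.23 log units; within the scatter) stays within it. All three compounds share the same core and the same side chain on the pyridine-type ring; they differ only in the group on the saturated chain carbon bound to the ring nitrogen.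

Compound 4, `C[C@H](Nc1c(C(N)=O)nnc2ccc(-c3ccc(NCCN(C)C)nc3)cc12)C1CCOCC1`, changes a different part of the molecule: (2-(dimethylamino)ethyl)amino in place of 3-(dimethylamino)propoxy on an aromatic carbon, next to the ring nitrogen and para to a large group. Among the measured compounds shown here, none of the measured steps touch this side chain, so they give no direct guide to what this change does in this assay; the only anchor is the value of compound 1. With no evidence for movement in either direction, the expectation is a step of about a 1.2-fold higher number from compound 1 to compound 4 (0.07 log units; within the scatter), not beyond the scatter. Compound 4 is therefore estimated at 4 uL/min, most likely between 1.7 uL/min and 9 uL/min.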

Compound 4, intrinsic clearance in a liver preparation (reported as CLH), per the amount of preparation that the assay uses: 4.2 uL/min
The estimate for compound 4 lay 1.1-fold (0.02 log units) below the measured number; the measured number falls inside the stated range.
By their numbers in this assay, from the lowest: compounds 1, 4, 2 and 3 (each within the scatter of the next, the first and the last beyond it).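

Among the compounds shown here, replacing 3-(dimethylamino)propoxy with (2-(dimethylamino)ethyl)amino is the first change to this side chain, and in this assay it gives a 1.2-fold higher number from compound 1 to compound 4 (0.09 log units; within the scatter). With the oxan-4-yl group in place, the side chain can therefore exchange its oxygen for a nitrogen and gain a hydrogen-bond donor without a shift that stands out from the scatter. No supporting measurement explains why the number holds steady.

On these data alone, the same exchange is untested here on the 1-methyl-1H-pyrazol-3-yl group of compound 2 or the 1,4-dimethyl-1H-pyrazol-3-yl group of compound 3, so it may not carry over to them. Also open, as far as these compounds go, is how this assay would respond to a longer chain, such as (3-(dimethylamino)propyl)amino, or to a ring-bearing amine, such as a piperidine, on this aromatic carbon.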